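Replacing the hydroxy hydrogen of compound 1

The compounds below may be only part of what the source reports. "The series", "measured", "known", "first", "only" and "open" are said of these compounds alone.

- compound 1 `C=C1C(=O)[C@@]23C(=O)OC[C@]4(C(=O)CCC(C)(C)[C@H]4C=O)[C@@H]2CC[C@@H]1[C@H]3O` gives 5030 nM
- compound 2 `C=C1C(=O)[C@@]23C(=O)OC[C@]4(C(=O)CCC(C)(C)[C@H]4C=O)[C@@H]2CC[C@@H]1[C@H]3OC(=O)c1ccc(OC)cc1` gives 2800 nM

Going by the values given here, in a functional assay on Bel-7402 cells (Homo sapiens) for cytotoxicity, read by MTT assay, with a stated time of 72 h (on this read-out higher numbers stand for weaker inhibition and lower numbers for stronger inhibition), compound 1 stands within the scatter of compound 2, its only measured neighbour. Compound 3 `C=C1C(=O)[C@@]23C(=O)OC[C@]4(C(=O)CCC(C)(C)[C@H]4C=O)[C@@H]2CC[C@@H]1[C@H]3OC(=O)c1ccc([N+](=O)[O-])cc1` carries the change (4-nitrophenyl)carbonyl in place of hydrogen on an oxygen on a saturated carbon on the core of compound 1. Among the compounds with values here, the sole step bearing on it leads to compound 2 (a 1.8-fold lower number from compound 1 to compound 2 (0.25 log units; within the scatter)), where (4-methoxyphenyl)carbonyl replaces the same hydrogen. With that one guide, no shift beyond the scatter is expected in this assay. The estimate means an expected step (a 1.7-fold lower number from compound 1 to compound 3 (0.22 log units; within the scatter)) with no firm direction. Compound 3 is expected at 3000 nM (estimated range 1200 nM to 7000 nM).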

Compound 3, half-maximal inhibitory concentration: 3300 nM
Compound 3: middle estimate off by 1.1-fold (0.04 log units), on the low side; measured number inside the range.
By their numbers in this assay, from the lowest: compounds 2, 3 and 1 (each within the scatter of the next).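

In this assay, a second ester on the oxygen again leaves the number within the scatter (a 1.5-fold lower number from compound 1 to compound 3 (0.18 log units; within the scatter)). The first comparison within the aromatic ring of the esters, nitro in place of methoxy on an aromatic carbon, also stays within the scatter (a 1.2-fold higher number from compound 2 to compound 3 (0.07 log units; within the scatter)), so these two opposite-looking substituents are not told apart at this position. No measurement bearing on the reason for this is available.

Open, going by these compounds, is whether an amine or a carboxylic acid on the aromatic ring, or a longer alkyl chain in place of that ring, would move the number beyond the scatter.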